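The compounds below may be only part of what the source reports. "The series", "measured", "known", "first", "only" and "open" are said of these compounds alone.

Compounds measured:
- compound 1, `CCN1CCN(c2c(C(C)=O)c(=O)oc3cc(Nc4nccc(-c5ccc(F)cc5OC)n4)ccc23)CC1`: 740 nM
- compound 2, `COc1ccccc1-c1ccnc(Nc2ccc3c(C)c(C(C)=O)c(=O)oc3c2)n1`: 10200 nM
- compound 3, `COc1cc(F)ccc1-c1nc(Nc2ccc3c(N4CCCNCC4)c(C(C)=O)c(=O)oc3c2)ncc1F`: 420 nM

Of the compounds shown here, three sharing one core have been tested in a functional assay on MV4-11 cells (Homo sapiens) for inhibition, read by luminescence and CellTiter-Glo, with a stated time of 72 h; a higher number here means a weaker inhibitor, a lower number a stronger inhibitor. Compound 3 gives the lowest number of the three. Its neighbour is compound 1, whose value lies within the usual scatter of compound 3, so the two cannot be told apart; compound 2 stands well beyond the scatter, with a much higher number.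

Compound 4, `COc1cc(F)ccc1-c1nc(Nc2ccc3c(N4CCN(C)CC4)c(C(C)=O)c(=O)oc3c2)ncc1F`, has not yet been tested. It differs from compound 3 in one place: 4-methylpiperazin-1-yl in place of 1,4-diazepan-1-yl on an aromatic carbon. Among the measured compounds shown here, no measured pair shows exactly this exchange. Compound 1 carries a closely related group at the same place and sits within the scatter of compound 3, so for the step from compound 3 to compound 4 no change beyond the scatter is expected, in either direction: a 1.2-fold higher number from compound 3 to compound 4 (0.08 log units; within the scatter). Compound 4 is therefore expected to give about 500 nM in this assay, most likely between 200 nM and 1500 nM.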

Compound 4, half-maximal inhibitory concentration: 400 nM
Estimate against measurement, compound 4: 1.3-fold (0.10 log units) above; the range from low to high includes it.
By their numbers in this assay, from the lowest: compounds 4, 3 and 1 (each within the scatter of the next); then compound 2.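

In this assay, among the compounds shown here, the step of a 1.1-fold lower number from compound 3 to compound 4 (0.02 log units; within the scatter) is the first direct reading at this position, on an aromatic carbon opposite the ring oxygen, and the two compounds cannot be told apart. The seven-membered ring of 1,4-diazepan-1-yl, with its hydrogen-bond donor, and the six-membered ring of 4-methylpiperazin-1-yl, with none, therefore serve equally well here in this cell read-out, at least on this core. Nothing shown explains this outcome.

The compounds shown leave open whether a ring without a second nitrogen, such as morpholin-4-yl, or an open-chain amine such as dimethylamino would also fit at this position. They also leave open whether unsubstituted piperazin-1-yl would match its 4-methyl counterpart, which would separate the effect of ring size from that of the methyl group.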